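Cyclohexyl in place of butenyl: expected acid dissociation

A few compounds are considered here, and "the series" means these few. Any claim that something is new, unique, unknown or untested is made for them only; others in the source may bear on it.

Of the compounds shown here, three of the shared core have been measured in a physicochemical assay for acid dissociation. Compound 1 `CC(C)CCN(C1=NCCN1)c1c(Br)cccc1Br` gives 10.9. Compound 2 `C=C(C)CN(C1=NCCN1)c1c(Br)cccc1Br` gives 10.7, and compound 3 `C/C=C/CN(C1=NCCN1)c1c(Br)cccc1Br` gives 11. On the numbers shown compound 3 stands highest of the three, yet the other two lie close: a number 0.10 log units higher from compound 1 to compound 3 (within the scatter) and a number 0.30 log units higher from compound 2 to compound 3 (within the scatter), both within the scatter, as is a number 0.20 log units lower from compound 1 to compound 2 (within the scatter). The three groups on the nitrogen bound to the aromatic ring thus leave the read-out essentially unchanged.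

Compound 4 `Brc1cccc(Br)c1N(C1=NCCN1)C1CCCCC1` is not yet measured. It differs from compound 3 in one place: cyclohexyl in place of but-2-en-1-yl on a nitrogen on an aromatic ring. The change again replaces the group on this nitrogen, so the three measured steps bear on it; none of them moved the number beyond the scatter. A saturated ring in this position has not been measured in the series, so the step to compound 4 rests on that limited set. No step beyond the scatter is expected in this assay for compound 4. The estimated step of a number 0.10 log units lower from compound 3 to compound 4 (within the scatter) is expected to stay within the scatter. Compound 4 is estimated at 10.9, with a range from 10.5 to 11.3.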

Compound 4, acid dissociation constant: 11.3
Compound 4: the middle estimate sits 0.40 log units below what was measured; measured number inside the range.
By their numbers in this assay, from the lowest: compounds 2, 1, 3 and 4 (each within the scatter of the next, the first and the last beyond it).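

In this assay, going by these compounds alone, cyclohexyl on a nitrogen on an aromatic ring gives the first steps in this set that lie beyond the scatter, both modest (a number 0.60 log units higher from compound 2 to compound 4 (beyond the scatter)) and (a number 0.40 log units higher from compound 1 to compound 4 (beyond the scatter)). The position is therefore not wholly indifferent to the group it carries, although the three open chains had suggested that it might be. The separation is incomplete, however, as cyclohexyl in place of but-2-en-1-yl stays within the scatter (a number 0.30 log units higher from compound 3 to compound 4 (within the scatter)), and nothing available bears on why the read-out responds in this way.

Cyclohexyl differs from the open chains both in having a ring and in its larger carbon count, and no compound here separates these two features. Cyclopentyl, phenyl, a longer unbranched chain, or a chain bearing an amine or a carboxylic acid on this nitrogen could show whether the steps belong to cyclohexyl alone and how far the read-out can move from this position.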